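Dropping One Chloro Group: Expected Effect on Growth Inhibition

This account rests on a few compounds, and the source may have more. Where it says the series, first, only, none or still open, it means among the compounds named here.

Compound 3 `ClCc1cccc(Cn2cnc3c(Cl)nc(Cl)nc32)c1` and compound 1 `ClCc1cccc(Cn2cnc3c(Cl)ncnc32)c1` share a core and differ only by hydrogen in place of chloro on an aromatic carbon. In a functional assay on NCI/ADR-RES cells (Homo sapiens) for cytotoxicity, read by sulforhodamine B assay, with a stated time of 48 h (a lower number here means a stronger inhibitor of growth, a higher number a weaker inhibitor of growth), compound 3 gives 5240 nM, while compound 1 gives 7580 nM; the step is a 1.4-fold higher number from compound 3 to compound 1 (0.16 log units; within the scatter). Compound 2 `ClCc1ccc(Cn2cnc3nc(Cl)nc(Cl)c32)cc1` gives 4460 nM in this assay; compound 2 and compound 3 carry the same atoms joined differently, and the difference between the two cores is not broken down here. Their two numbers lie within the scatter of one another. Compound 4 `ClCc1ccc(Cn2cnc3ncnc(Cl)c32)cc1` awaits measurement; it differs from compound 2 by hydrogen in place of chloro on an aromatic carbon, the same kind of change as that from compound 3 to compound 1. For compound 4 a step of a 1.4-fold higher number from compound 2 to compound 4 (0.14 log units; within the scatter) is expected, because the earlier step of a 1.4-fold higher number from compound 3 to compound 1 (0.16 log units; within the scatter) stayed within the scatter. Compound 4 is estimated at 6200 nM, expected between 3000 nM and 13000 nM.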

Compound 4, concentration for total growth inhibition: 4670 nM
Compound 4: the middle estimate sits 1.3-fold (0.12 log units) above what was measured, within the range that was stated.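

In this assay, hydrogen in place of chloro on an aromatic carbon gives a 1.0-fold higher number from compound 2 to compound 4 (0.02 log units; within the scatter), a step within the scatter. Set beside the earlier step, the change carries from one core to the other with no difference that can be told apart: the same change on two cores in this assay, a 1.4-fold higher number (0.16 log units; within the scatter) from compound 3 to compound 1 and a 1.0-fold higher number (0.02 log units; within the scatter) from compound 2 to compound 4, 1.4-fold (0.14 log units) apart, within the scatter of two such steps. Going by these compounds alone, this shows only that the step stays within the scatter on both cores; it rests on a single pair per core, gives no direction for the change, and does not show how the change would behave on any other core.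

Only chloro and hydrogen appear on the aromatic carbon between two ring nitrogen atoms. The compounds shown leave open what an amine or a methoxy group there would do.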